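This account rests on a few compounds, and the source may have more. Where it says the series, first, only, none or still open, it means among the compounds named here.

Compound 1 `CCCC(=O)N1N=C(c2cc(OC)ccc2N)SC1(C)C` stands lowest of the two measured numbers: in an assay on isolated protein for inhibition of Nitric oxide synthase, inducible (Homo sapiens), read by scintillation counting, with a stated time of 30 min, tested at 50 uM (a higher number here means more inhibition at the concentration tested (going by the name of the read-out), a lower number less inhibition), compound 1 gives 91.1%, while compound 2 `CCCCC(=O)N1N=C(c2cc(OC)ccc2N)SC1(C)C` gives 101%. Between these two lies the step of a number 9.9 percentage points higher from compound 1 to compound 2 (within the scatter). Compound 3 `COc1ccc(N)c(C2=NN(C(=O)C3CCC3)C(C)(C)S2)c1` differs from compound 1 by cyclobutyl in place of propyl on a carbonyl carbon. Among the measured compounds shown here, the one measured step that bears on this change is the lengthening at the same carbonyl carbon, and that step stayed within the scatter. One therefore expects no step beyond the scatter either; the expected step is a number 2.9 percentage points higher from compound 1 to compound 3 (within the scatter). The estimate for compound 3 in this assay is 94%, with a range from 80% to 105%.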

Compound 3, a percentage reported as inhibition, at one concentration (the size of the read-out at that concentration, not a potency): 57.8%
Estimate against measurement, compound 3: 36.2 percentage points above; the whole stated range lies above it.
By their numbers in this assay, from the lowest: compound 3; then compounds 1 and 2 (each within the scatter of the next).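

In this assay, the carbonyl carbon proved sensitive to the form of its substituent, which the earlier chain lengthening had not shown: cyclobutyl in place of propyl gave a number 33.3 percentage points lower from compound 1 to compound 3 (beyond the scatter), and cyclobutyl in place of butyl gave a number 43.2 percentage points lower from compound 2 to compound 3 (beyond the scatter). Among these three groups, only the ring stands apart, as the propyl and butyl compounds lie within the scatter of each other. Nothing shown here explains the drop. As far as these compounds go, whether isopropyl on the same carbonyl carbon would keep the numbers of the open chains, or cyclopentyl would follow cyclobutyl, remains open.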